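Trimethylphenyl Amide in the Piperidine Series: An Expected Value

A few compounds are considered here, and "the series" means these few. Any claim that something is new, unique, unknown or untested is made for them only; others in the source may bear on it.

Measured so far in a functional assay on K562 cells (Homo sapiens) for cytotoxicity, read by WST assay, with a stated time of 72 h; on this read-out higher numbers stand for weaker inhibition and lower numbers for stronger inhibition:
compound 1 `COc1cc2c(Nc3nc4ccc(C(=O)Nc5c(C)cc(C)cc5C)cc4s3)ncnc2cc1OCCCN1CCC(C)CC1` gives 5900 nM;
compound 2 `COc1cc2c(Nc3nc4ccc(C(=O)Nc5c(C)cccc5C)cc4s3)ncnc2cc1OCCCN1CCCCC1` gives 13700 nM;
compound 3 `COc1cc2c(Nc3nc4ccc(C(=O)Nc5c(C)cccc5Cl)cc4s3)ncnc2cc1OCCCN1CCCCC1` gives 12500 nM.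

Compound 3 holds the second highest of the three numbers. Its value sits close to that of compound 2, within the scatter, while the number of compound 1 is clearly lower. Compound 4 `COc1cc2c(Nc3nc4ccc(C(=O)Nc5c(C)cc(C)cc5C)cc4s3)ncnc2cc1OCCCN1CCCCC1` differs from compound 3 by 2,4,6-trimethylphenyl in place of 2-chloro-6-methylphenyl on an amide-type nitrogen. Among the measured compounds shown here, the only measured step on this amide aryl group, a 1.1-fold lower number from compound 2 to compound 3 (0.04 log units; within the scatter), stayed within the scatter, so the exchange of chloro back for methyl alone carries little weight. The added methyl brings compound 4 nearer in structure to compound 1, whose value is the lowest shown. Compound 4 is therefore expected to show a modest step downward, a 1.4-fold lower number from compound 3 to compound 4 (0.14 log units; within the scatter), landing at an estimated 9000 nM with a range from 4000 nM to 20000 nM.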

Compound 4, half-maximal inhibitory concentration: 9300 nM
Beside the measured number, compound 4's estimate is 1.0-fold (0.01 log units) below it; the measured number falls inside the stated range.
By their numbers in this assay, from the lowest: compounds 1, 4, 3 and 2 (each within the scatter of the next, the first and the last beyond it).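

In this assay, the full exchange on the amide-type nitrogen gave a 1.3-fold lower number from compound 3 to compound 4 (0.13 log units; within the scatter), while adding one methyl on an aromatic carbon gave a 1.5-fold lower number from compound 2 to compound 4 (0.17 log units; within the scatter). Replacing methyl with hydrogen on a saturated ring carbon gave a 1.6-fold higher number from compound 1 to compound 4 (0.20 log units; within the scatter), so each of these single changes stays within the scatter. Nothing available accounts for these small steps. Still open, going by these compounds, is whether a carboxylic acid or a dimethylamino group in place of that aromatic methyl would move the number beyond the scatter.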